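The compounds below may be only part of what the source reports. "The series", "measured", "known", "first", "only" and "open" are said of these compounds alone.

Compound 1 `Cn1nnnc1SCC(=O)N/N=C/c1ccccc1` was tested in a functional assay on A549 cells (Homo sapiens) for cytotoxicity, read by XTT assay, with a stated time of 24 h (a higher number here means a weaker inhibitor, a lower number a stronger inhibitor), and in that test compound 1 gives 3160000 nM. Compound 2 `Cn1nnnc1SCC(=O)N/N=C/c1ccc(Cl)cc1` differs from compound 1 in one place only, (chloro in place of hydrogen on an aromatic carbon), and in this assay compound 2 gives 100000 nM. That single change made a 32-fold lower number from compound 1 to compound 2 (1.50 log units; beyond the scatter). Compound 3 `C/C(=N\NC(=O)CSc1nnnn1C)c1ccc(Cl)cc1` stands on a different core; the difference between its core and the core of compound 1 is not broken down here. In this assay compound 3 gives 6000000 nM, a number that sits close to the number of compound 1 and far from the number of compound 2.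

Compound 4 `C/C(=N\NC(=O)CSc1nnnn1C)c1ccc(Cl)cc1Cl` has not been measured. It arises from compound 3 through (chloro in place of hydrogen on an aromatic carbon). For the measured compounds named here, this is the same kind of change as the one from compound 1 to compound 2, but not the same change: there the chloro entered para to a large group, whereas here it enters ortho to a large group and meta to a chloro group. Going by the values given here, the one earlier example gave a large gain, so a gain is expected here too, but with a second chloro added at a place that is not the same, and with only that single example behind it, a smaller step is the more cautious expectation. Compound 4 is expected to show a 5.0-fold lower number from compound 3 to compound 4 (0.70 log units; beyond the scatter) in this assay. For compound 4 the estimate in this assay is 1200000 nM, most likely between 200000 nM and 6000000 nM.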

Compound 4, half-maximal inhibitory concentration: 800000 nM
The estimate for compound 4 lay 1.5-fold (0.18 log units) above the measured number; measured number inside the range.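

In this assay, putting a chloro on the aromatic ring of compound 3 again lowered the number, giving a 7.5-fold lower number from compound 3 to compound 4 (0.88 log units; beyond the scatter), so the direction of this change carried over from one core to the other. The size of the step did not carry over, and the gap between the two steps is larger than repeated measurements alone would be expected to produce: the same change on two cores in this assay, a 32-fold lower number (1.50 log units; beyond the scatter) from compound 1 to compound 2 and a 7.5-fold lower number (0.88 log units; beyond the scatter) from compound 3 to compound 4, 4.2-fold (0.62 log units) apart, beyond the scatter of two such steps. For the compounds shown here, with only one pair on each core, and with the chloro entering a different place in compound 4, ortho to a large group and meta to a chloro group, these numbers cannot show whether the smaller step belongs to the core, to the new place on the ring, or to the chloro already present in compound 3.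

The compounds shown carry only hydrogen or chloro on the aromatic ring, so it stays open whether a fluoro, a methoxy or an amine would shift the number in the same direction. As far as these compounds go, it also stays open whether a single chloro ortho to a large group, with no second chloro on the ring, would give a step of similar size on the core of compound 1.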